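Sulfonyl chain extension in an indole series at the serotonin receptor

A few compounds are considered here, and "the series" means these few. Any claim that something is new, unique, unknown or untested is made for them only; others in the source may bear on it.

Measured compounds:
- compound 1 `CN(C)c1cccc2c1ccn2S(C)(=O)=O`: 4720 nM
- compound 2 `CCCCS(=O)(=O)n1ccc2c(N(C)C)cccc21`: 49900 nM
- compound 3 `CS(=O)(=O)n1ccc2ccc(-c3ccncc3)cc21`: 4050 nM

All three were tested in an assay on isolated protein for displacement of a labelled ligand from 5-hydroxytryptamine receptor 6 (Homo sapiens), read by scintillation counting, with a stated time of 1 h; a lower number here means a stronger inhibitor, a higher number a weaker inhibitor. Compound 1 gives 4720 nM in this assay. Relative to compound 1 there is one change, (propyl in place of hydrogen on a saturated chain carbon bound to a sulfonyl sulfur), and with it compound 2 gives 49900 nM; the step is an 11-fold higher number from compound 1 to compound 2 (1.02 log units; beyond the scatter). Compound 3 rests on a different core, and the difference between the two cores is not broken down here. In this assay compound 3 gives 4050 nM, which sits within the scatter of compound 1.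

Compound 4 `CCCCS(=O)(=O)n1ccc2ccc(-c3ccncc3)cc21` has not been measured. It differs from compound 3 by propyl in place of hydrogen on a saturated chain carbon bound to a sulfonyl sulfur, the same change that was made from compound 1 to compound 2. Among the compounds with values here, the expected step of a 9.9-fold higher number from compound 3 to compound 4 (0.99 log units; beyond the scatter) is set close to the earlier one, because an 11-fold higher number from compound 1 to compound 2 (1.02 log units; beyond the scatter) is the only measured example of this change. The value expected for compound 4 in this assay is 40000 nM, with a range from 12000 nM to 130000 nM.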

Compound 4, inhibition constant: 1150 nM
Beside the measured number, compound 4's estimate is 35-fold (1.54 log units) above it; measured number outside the range, below it.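

In this assay, methylsulfonyl to butylsulfonyl gives a 3.5-fold lower number from compound 3 to compound 4 (0.55 log units; beyond the scatter), so the change does not carry over between the two cores, and the direction of the step reverses: the same change on two cores in this assay, an 11-fold higher number (1.02 log units; beyond the scatter) from compound 1 to compound 2 and a 3.5-fold lower number (0.55 log units; beyond the scatter) from compound 3 to compound 4, 37-fold (1.57 log units) apart, beyond the scatter of two such steps

Within the data shown here, in this series, the step on one core is therefore no guide to the step on the other. These two pairs do not show which difference between the cores lies behind the reversal, and one pair per core shows nothing about how the numbers follow chain length.

Open, going by these compounds, is how ethylsulfonyl, propylsulfonyl or a longer chain such as hexylsulfonyl would read on each core. Also open, on these data alone, is whether a chain ending in an amine or a carboxylic acid would follow the same split.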